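Removing the Methoxy Group: Expected Clearance of Compound 3

This account rests on a few compounds, and the source may have more. Where it says the series, first, only, none or still open, it means among the compounds named here.

Measured compounds:
compound 1, `COc1ccc2c(=O)c(C)c(-c3cncc(-c4ccc(OC(F)(F)F)cc4)c3)[nH]c2c1`, 25.9 uL/min
compound 2, `Cc1c(-c2cncc(-c3ccc(Cl)c(Cl)c3)c2)[nH]c2ccccc2c1=O`, 5.6 uL/min

Both compounds were run in an ADME assay on liver for metabolic stability, with Liver microsome (Homo sapiens) as the target, read by LC-MS, using microsomes and NADPH, with a stated time of 45 min, tested at 3 uM; on this read-out lower numbers stand for slow clearance and higher numbers for fast clearance. Compound 1 gives 25.9 uL/min, the highest of the two numbers measured. Its nearest neighbour is compound 2 with 5.6 uL/min, a gap that lies beyond the usual scatter; compound 2 differs from compound 1 in more than one place, so its value is reported only for what it shows.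

Compound 3, `Cc1c(-c2cncc(-c3ccc(OC(F)(F)F)cc3)c2)[nH]c2ccccc2c1=O`, has not yet been measured in this assay. Within the data shown here, it differs from compound 1 by hydrogen in place of methoxy on an aromatic carbon, and no step between measured compounds reproduces this change. Among the measured compounds shown here, a step of modest size toward slower clearance is expected, a 2.2-fold lower number from compound 1 to compound 3 (0.33 log units; beyond the scatter), on the grounds that the only other measured compound, compound 2, lacks the methoxy and gives 5.6 uL/min. Compound 3 is therefore estimated at 12 uL/min, within 5 uL/min to 28 uL/min.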

Compound 3, intrinsic clearance in a liver preparation (reported as CLH), per the amount of preparation that the assay uses in the Liver microsome assay: 12.5 uL/min
Estimate against measurement, compound 3: 1.0-fold (0.02 log units) below; low and high end bracket the measured number.
By their numbers in the Liver microsome assay, from the lowest: compound 2; then compound 3; then compound 1.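

Among these compounds, this is the first step that isolates the methoxy on this aromatic carbon: in the Liver microsome assay, replacing it with hydrogen gives a 2.1-fold lower number from compound 1 to compound 3 (0.32 log units; beyond the scatter), so the carbon is a place where a single change separates two compounds on clearance. In a physicochemical assay for solubility, measured as kinetic solubility, at pH 7.4, tested at 200 uM (on this read-out higher numbers stand for higher solubility and lower numbers for lower solubility), compound 1 gives < 1000 nM, which is a limit of the assay and not a number: the limit of < 1000 nM in the physicochemical assay, at which 1 of the 2 values shown sits. In the physicochemical assay compound 3 gives 3600 nM, a measured number and not a limit, so two compounds differing only at this carbon also stand apart on solubility.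

The compounds shown leave open how a fluorine or an amine on this carbon would read on either measure. From the compounds shown here alone, it also remains open whether adding a methoxy to compound 2 would give a step of like size.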